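Trifluoromethyl for phenyl on the triazole of compound 2

The source may hold more compounds than are shown below. What is called first, only, known or untested is meant among the compounds shown, and "the series" means these compounds.

Measured compounds:
compound 1, `COc1cc(-c2nc(N)n(CC(=O)Nc3ccc(/C(C)=N\O)cc3)n2)cc(OC)c1OC`: 12.1%
compound 2, `C/C(=N/O)c1ccc(NC(=O)Cn2nc(-c3ccccc3)nc2N)cc1`: 15.2%
compound 3, `COc1ccc(-c2nc3sc(-c4ccc(Cl)cc4)cn3n2)cc1`: 50.6%

Of the compounds shown here, three have been measured in a functional assay on SK-OV-3 cells (Homo sapiens) for inhibition, read by sulforhodamine B assay, with a stated time of 48 h, tested at 10 uM; a lower number here means less inhibition of growth, a higher number more inhibition of growth at the concentration tested. Compound 2 gives 15.2%, which is the second highest of the three numbers. Its nearest neighbour is compound 1, which gives 12.1%, a number that lies within the scatter of compound 2, so no order can be read between the two. Compound 3, built on a different core, gives 50.6%, a number far above that of compound 2 and beyond the scatter.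

Compound 4, `C/C(=N/O)c1ccc(NC(=O)Cn2nc(C(F)(F)F)nc2N)cc1`, has not yet been measured. It differs from compound 2 in one place: trifluoromethyl in place of phenyl on an aromatic carbon. The group sits on an aromatic carbon of a five-membered aromatic ring with three nitrogen, between two ring nitrogen atoms, two ring bonds from the ring atom that bears an amino group.

Among the measured compounds shown here, no measured pair shows this kind of change, and the only comparison available, compound 1 against compound 2, shows a swap at the same position that stays within the scatter. The expectation for this assay is therefore a step from compound 2 to compound 4 of no size beyond the scatter, a number 2.2 percentage points lower from compound 2 to compound 4 (within the scatter). Compound 4 is expected to give 13%, with a range from 3% to 28%.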

Compound 4, percent growth inhibition at one concentration: 3.53%
Beside the measured number, compound 4's estimate is 9.5 percentage points above it; the range from low to high includes it.
By their numbers in this assay, from the lowest: compounds 4, 1 and 2 (each within the scatter of the next, the first and the last beyond it); then compound 3.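

In this assay, the aromatic carbon between two ring nitrogen atoms now gives a readable single-place step: trifluoromethyl in place of phenyl brings a number 11.7 percentage points lower from compound 2 to compound 4 (beyond the scatter), a modest step but one beyond the scatter. The position is therefore not indifferent to its group, at least in this pair, where a six-membered aromatic ring of carbon only gives way to a group with no ring and the growth inhibition at the tested concentration falls. Nothing measured on these compounds explains why the number falls with this change.

The compounds shown leave open whether the step follows the loss of the ring or the arrival of trifluoromethyl, and a plain methyl at this position would separate the two readings. They also leave open whether a ring that carries an amine or a carboxylic acid, or a longer chain such as n-butyl, would lie nearer to compound 2 or to compound 4, and whether any group here could lift the number well beyond that of compound 2.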